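The source may hold more compounds than are shown below. What is called first, only, known or untested is meant among the compounds shown, and "the series" means these compounds.

Measured so far:
- compound 1 `Nc1ccc(-c2cc(=O)c3c(N)c(F)c(Cl)c(F)c3o2)cc1F`: > 100000 nM
- compound 2 `CN(C)CCCC(=O)OCc1c(F)c(N)c2c(=O)cc(-c3ccc(N)c(F)c3)oc2c1F`: 4500 nM

Both compounds were tested in a functional assay on HeLa cells (Homo sapiens) for cytotoxicity, read by neutral red uptake, with a stated time of 3 days; a higher number here means a weaker inhibitor, a lower number a stronger inhibitor. For compound 1 the value is a limit of the assay, > 100000 nM. Going by the values given here, compound 2 gives 4500 nM, the only number among the values shown. Among the compounds with values here, the one measured step, an at least 22-fold lower number from compound 1 to compound 2 (1.34 log units; beyond the scatter), starts from the limit of > 100000 nM in this assay, at which 1 of the 2 values shown sits. Compound 3 `CN(C)Cc1c(F)c(N)c2c(=O)cc(-c3ccc(N)c(F)c3)oc2c1F` differs from compound 2 by dimethylamino in place of ((3-(dimethylamino)propyl)carbonyl)oxy on a saturated chain carbon bound to an aromatic carbon. That step added the whole group at once, so the data do not separate the dimethylamino part from the ester part. Compound 3 is therefore estimated at 8000 nM (range 2000 nM to 40000 nM), an expected step of a 1.8-fold higher number from compound 2 to compound 3 (0.25 log units; within the scatter).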

Compound 3, half-maximal inhibitory concentration: 8900 nM
Compound 3: the middle estimate sits 1.1-fold (0.05 log units) below what was measured; the measured number falls inside the stated range.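

Compound 2 and compound 3 cannot be told apart in this assay, with a 2.0-fold higher number from compound 2 to compound 3 (0.30 log units; within the scatter), so the ((3-(dimethylamino)propyl)carbonyl)oxy group is not needed to keep the reading of compound 2. The (dimethylamino)methyl group alone, in place of chloro on an aromatic carbon, gives a step beyond the scatter, an at least 11-fold lower number from compound 1 to compound 3 (1.05 log units; beyond the scatter). The starting value of compound 1 is a limit and not a number: the limit of > 100000 nM in this assay, at which 1 of the 3 values shown sits.

Still open, on these data alone, is what a plain methyl or a hydroxymethyl group on that aromatic carbon would give, and so whether the amine nitrogen matters. Also open, as far as these compounds go, is whether a primary amine or a longer chain would read the same.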